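This account rests on a few compounds, and the source may have more. Where it says the series, first, only, none or still open, it means among the compounds named here.

Measured compounds:
Compound 1, `N#Cc1ccccc1-c1ccc(CSc2ncnc3ccccc23)cc1`: > 100000 nM
Compound 2, `Cc1nc(SCc2ccc(-c3ccccc3C#N)cc2)c2ccccc2n1`: > 100000 nM
Compound 3, `N#Cc1ccccc1-c1ccc(CSc2nc(SCc3ccc(F)cc3)nc3ccccc23)cc1`: > 100000 nM

In an assay on isolated protein for inhibition of phosphodiesterase 7 (Homo sapiens), read by scintillation proximity assay and cAMP accumulation, with a stated time of 1 h (on this read-out higher numbers stand for weaker inhibition and lower numbers for stronger inhibition), compound 1 gives > 100000 nM, which is a limit of the assay rather than a number. Compound 2 also sits at a limit, > 100000 nM. Compound 3 likewise gives only a limit, > 100000 nM. For the measured compounds named here, because of the limit of > 100000 nM in this assay, at which 3 of the 3 values shown sit, none of the measured steps can be read: a step that the two limits leave unreadable from compound 1 to compound 2, a step that the two limits leave unreadable from compound 1 to compound 3 and a step that the two limits leave unreadable from compound 2 to compound 3 all stay hidden.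

Compound 4, `N#Cc1ccccc1-c1ccc(CSc2nc(SCc3ccc([N+](=O)[O-])cc3)nc3ccccc23)cc1`, differs from compound 1 by (4-nitrobenzyl)sulfanyl in place of hydrogen on an aromatic carbon. The nearest measured comparison is compound 3, which carries a (4-fluorobenzyl)sulfanyl at the same aromatic carbon and still shows only a limit, > 100000 nM. With every value at the limit and no readable step, no direction can be predicted in this assay beyond the scatter. Compound 4 is therefore expected to give around 100000 nM, within 30000 nM to 300000 nM, most likely again as a limit. That estimate corresponds to an expected step of a number no higher from compound 1 to compound 4 (the limit leaves the size open).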

Compound 4, half-maximal inhibitory concentration: > 100000 nM
Compound 4 gave a limit, no number (the forecaster's own chance of this, stated with the estimate: 85%); the middle value sits exactly at the limit.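

No new step can be read between compound 4 and compound 1, compound 2 or compound 3, because each result is a limit and not a number: the limit of > 100000 nM in this assay, at which 4 of the 4 values shown sit.

The compounds shown leave open whether any change to the shared core would give a true number in this assay, and so how these groups compare.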